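A few compounds are considered here, and "the series" means these few. Any claim that something is new, unique, unknown or untested is made for them only; others in the source may bear on it.

- compound 1 `CCNc1nc(SCc2nc3ccccc3[nH]2)nc(-c2ccccc2)c1C#N`: 7.35 nM
- compound 2 `N#Cc1c(NC(N)=S)nc(SCc2nc3ccccc3[nH]2)nc1-c1ccccc1`: 3.2 nM

Among the measured compounds shown here, in a functional assay on KB cells (Homo sapiens) for cytotoxicity, read by MTT assay, with a stated time of 3 days (on this read-out higher numbers stand for weaker inhibition and lower numbers for stronger inhibition), compound 2 gives 3.2 nM, the lower of the two numbers measured so far, and the gap to compound 1 lies beyond the scatter. Compound 3 `CN1CCN(c2nc(SCc3nc4ccccc4[nH]3)nc(-c3ccccc3)c2C#N)CC1` replaces the open-chain group of compound 2 with 4-methylpiperazin-1-yl, on an aromatic carbon: a group of 7 heavy atoms (5 carbon, 2 nitrogen; one six-membered non-aromatic ring with 2 hetero atoms) in place of a group of 4 heavy atoms (1 carbon, 2 nitrogen, 1 sulfur; no ring), on an aromatic carbon. For the measured compounds named here, only one measured step bears on this change: a 2.3-fold lower number from compound 1 to compound 2 (0.36 log units; beyond the scatter), a modest step made on a nitrogen on an aromatic ring. Neither measured compound carries a ring in this group, so that step is only a loose guide. A modest step is expected again, with a slight lean towards a higher number in this assay, though the direction remains uncertain. The expected change is a 2.5-fold higher number from compound 2 to compound 3 (0.40 log units; beyond the scatter). Compound 3 is estimated at 8 nM, with an expected range of 2.5 nM to 30 nM.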

Compound 3, half-maximal inhibitory concentration: 2.7 nM
Estimate against measurement, compound 3: 3.0-fold (0.47 log units) above; the measured number falls inside the stated range.
By their numbers in this assay, from the lowest: compounds 3 and 2 (each within the scatter of the next); then compound 1.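

In this assay, replacing the open-chain group of compound 2 with 4-methylpiperazin-1-yl gives a 1.2-fold lower number from compound 2 to compound 3 (0.07 log units; within the scatter), so at this position a six-membered non-aromatic ring with 2 hetero atoms and 0 hydrogen-bond donors performs on a level with a group that has no ring and 2 hydrogen-bond donors. Set against ethylamino, the same ring gives a 2.7-fold lower number from compound 1 to compound 3 (0.43 log units; beyond the scatter), which is the first step showing that a ring on this aromatic carbon can stand in a modest way apart from an open-chain amine. Nothing measured here explains either step.

The compounds shown leave open how a morpholine or a piperazine without the methyl would compare with 4-methylpiperazin-1-yl. They also leave open whether the ring's terminal methyl contributes at all to the number seen for compound 3.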